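The compounds below may be only part of what the source reports. "The series", "measured", "known", "first", "only" and "open" are said of these compounds alone.

Working notes on the sulfamate series. Compound 3 `CC(C)CCN(CCC(C)C)c1cccc(C(=O)N2CCc3ccc(OS(N)(=O)=O)cc3C2)c1` gives 75.9% in an assay on HEK293 cells for inhibition of Steryl-sulfatase (Homo sapiens), tested at 1 uM (a higher number here means a stronger effect of the compound at the concentration tested, a lower number a weaker effect), and stands second highest of the three numbers measured: compound 1 `CCN(Cc1ccccc1)c1cccc(C(=O)N2CCc3ccc(OS(N)(=O)=O)cc3C2)c1` gives 69%, compound 2 `CCN(Cc1ccc(Br)cc1)c1cccc(C(=O)N2CCc3ccc(OS(N)(=O)=O)cc3C2)c1` gives 84.5%. Going by the values given here, the steps of a number 6.9 percentage points higher from compound 1 to compound 3 (within the scatter) and a number 8.6 percentage points lower from compound 2 to compound 3 (within the scatter) both lie within the scatter, while a number 15.5 percentage points higher from compound 1 to compound 2 (beyond the scatter) is the only step beyond it. Compound 4 `CCN(Cc1ccccn1)c1cccc(C(=O)N2CCc3ccc(OS(N)(=O)=O)cc3C2)c1` differs from compound 3 by ethyl((pyridin-2-yl)methyl)amino in place of diisopentylamino on an aromatic carbon. The two amine exchanges measured so far moved this assay only within the scatter, so no step beyond the scatter is expected here either; the expected step is a number 5.9 percentage points lower from compound 3 to compound 4 (within the scatter). Compound 4 is estimated at 70%, range 55% to 85%, because compound 1 gives 69% with the closest amine.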

Compound 4, a percentage reported as inhibition, at one concentration (the size of the read-out at that concentration, not a potency): 19.9%
Compound 4: the middle estimate sits 50.1 percentage points above what was measured; the measured number lies below the stated range.
By their numbers in this assay, from the lowest: compound 4; then compounds 1, 3 and 2 (each within the scatter of the next, the first and the last beyond it).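

In this assay this position does not accept every amine: ethyl((pyridin-2-yl)methyl)amino in place of diisopentylamino gives a number 56 percentage points lower from compound 3 to compound 4 (beyond the scatter) and, unlike the exchanges from compound 1 and compound 2 to compound 3, lies beyond the scatter. With the ethyl kept, a change of the aromatic ring alone is enough: pyridin-2-yl in place of phenyl gives a number 49.1 percentage points lower from compound 1 to compound 4 (beyond the scatter) and pyridin-2-yl in place of 4-bromophenyl gives a number 64.6 percentage points lower from compound 2 to compound 4 (beyond the scatter) on the same chain carbon. Nothing available here explains this loss.

Open, from the compounds shown here alone, is whether pyridin-3-yl or pyridin-4-yl behaves like pyridin-2-yl. Also open, going by these compounds, is whether a bromo on the pyridine ring recovers the number.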